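A few compounds are considered here, and "the series" means these few. Any claim that something is new, unique, unknown or untested is made for them only; others in the source may bear on it.

Among the measured compounds shown here, in a functional assay on HCT-116 cells (Homo sapiens) for inhibition, read by MTT assay, with a stated time of 48 h (on this read-out higher numbers stand for weaker inhibition and lower numbers for stronger inhibition), compound 1 (`COc1ccc(N(C)c2nc(C)nc3ccccc23)cc1OCCCCCC[Se]C#N`) gives 6180 nM and holds the higher of the two numbers so far. Compound 2 (`Cc1nc(N(C)c2ccc(OCC[Se]C#N)cc2)c2ccccc2n1`) gives 2290 nM and lies beyond the scatter from it. Compound 3 (`COc1ccc(N(C)c2nc(C)nc3ccccc23)cc1OCCCC[Se]C#N`) awaits measurement and departs from compound 1 in one place: a group of 3 heavy atoms (1 carbon, 1 nitrogen, 1 selenium; no ring) in place of a group of 5 heavy atoms (3 carbon, 1 nitrogen, 1 selenium; no ring), on a saturated chain carbon, four bonds along the chain from an oxygen on an aromatic ring on a saturated chain carbon, four bonds along the chain from an oxygen on an aromatic ring. For the measured compounds named here, no two measured compounds differ in one place only, so no measured step guides this change. Compound 2 has a shorter chain and shows 2290 nM as its number, but it differs from compound 1 elsewhere too. A small move to a lower number is therefore expected, and the estimated 1.5-fold lower number from compound 1 to compound 3 (0.19 log units; within the scatter) may stay within the scatter. For compound 3 the expected value is 4000 nM with an estimated range from 1500 nM to 9000 nM in this assay testing.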

Compound 3, half-maximal inhibitory concentration: 512 nM
Compound 3: the middle estimate sits 7.8-fold (0.89 log units) above what was measured, outside the stated range (below it).
By their numbers in this assay, from the lowest: compound 3; then compound 2; then compound 1.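

In this assay, the group of 3 heavy atoms in place of the group of 5 heavy atoms, on a saturated chain carbon, four bonds along the chain from an oxygen on an aromatic ring, gives a 12-fold lower number from compound 1 to compound 3 (1.08 log units; beyond the scatter). Among the compounds shown here, this is the first step between compounds that differ in one place, and it shows that this change alone, with the shared core untouched, moves the number well beyond the scatter. Nothing at hand accounts for the size of this step.

On these data alone, only these two chains can be compared on this core, so it stays open whether the number would keep falling with a still shorter chain or rise again. Also open, as far as these compounds go, is what sulfur in place of the selenium, or an amine in place of the nitrile, would do at the end of this chain.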